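Meta-halogen swap on the shared core

The source may hold more compounds than are shown below. What is called first, only, known or untested is meant among the compounds shown, and "the series" means these compounds.

Measured so far:
Compound 1, `CCc1ccccc1N1CCCC(=O)N1`, gives 39000 nM in an assay on isolated protein for inhibition of Polyunsaturated fatty acid 5-lipoxygenase (Homo sapiens); a higher number here means a weaker inhibitor, a lower number a stronger inhibitor.
Compound 2, `O=C1CCCN(c2cccc(Cl)c2)N1`, gives 2500 nM in this assay.

Within the data shown here, compound 2 holds the lowest of the two numbers in this assay; the only neighbour is compound 1, whose number is higher by an amount beyond the scatter. Among the measured compounds shown here, no pair of measured compounds differs in a single place, so no step size is on record.

Compound 3, `O=C1CCCN(c2cccc(F)c2)N1`, is the next member. It differs from compound 2 by fluoro in place of chloro on an aromatic carbon. With nothing measured that isolates this exchange, the expectation rests only on the standing of compound 2 and the general size of halogen swaps of this kind; a modest move toward a higher number, possibly no further than the scatter, is the working assumption. The step from compound 2 to compound 3 is accordingly estimated at a 2.4-fold higher number from compound 2 to compound 3 (0.38 log units; beyond the scatter).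

For compound 3 the expected value in this assay is 6000 nM, with a range from 2500 nM to 15000 nM.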

Compound 3, half-maximal inhibitory concentration: 5500 nM
Compound 3: the middle estimate sits 1.1-fold (0.04 log units) above what was measured, and the stated range covers the measured number.
By their numbers in this assay, from the lowest: compound 2; then compound 3; then compound 1.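

In this assay, among these compounds, the exchange of chloro for fluoro on an aromatic carbon, meta to a group of 7 heavy atoms, provides the first single-place step: a 2.2-fold higher number from compound 2 to compound 3 (0.34 log units; beyond the scatter) is modest in size but beyond the scatter. This shows that the position is sensitive to the identity of the halogen, even though the exchange swaps one heavy atom for one heavy atom and leaves the counts of rings, hydrogen-bond donors and hydrogen-bond acceptors and the net charge unchanged. No measured evidence bears on what lies behind this step.

Still open, going by these compounds, is how far this position accepts anything other than these two halogens: bromo, a nitrile, a methoxy group or an amine on the same aromatic carbon would extend the comparison beyond a single exchange. Also open, on these data alone, is whether fluoro in place of chloro gives a step of similar size on another aromatic carbon of the same ring, which a single pair of compounds cannot settle.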